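The compounds below may be only part of what the source reports. "The series", "measured", "known", "first", "only" and "open" are said of these compounds alone.

Working notes on the shared core of compound 3, `C#CCn1cc(C(=O)NC(CC(=O)Nc2ccccc2)c2ccccc2)c(=O)c2ccc(Cl)nc21`, in a functional assay on ECV-304 cells (Homo sapiens) for cytotoxicity, read by MTT assay, with a stated time of 72 h; on this read-out higher numbers stand for weaker inhibition and lower numbers for stronger inhibition. Compound 1, `C#CCn1cc(C(=O)NC(CC(=O)Nc2ccccc2)c2ccccc2)c(=O)c2cc(F)c(Cl)nc21`, gives only a limit of the assay, > 10000 nM. Compound 2, `C#CCn1cc(C(=O)NC(CC(=O)Nc2ccccn2)c2ccccc2)c(=O)c2ccc(Cl)nc21`, likewise reaches only a limit, > 10000 nM. Among the measured compounds shown here, compound 3 gives 4000 nM, the only proper number in the set. The values of compound 1 and compound 2 sit at a limit of the assay (the limit of > 10000 nM in this assay, at which 2 of the 3 values shown sit). Both measured steps end at compound 3: an at least 2.5-fold lower number from compound 1 to compound 3 (0.39 log units; beyond the scatter), and an at least 2.5-fold lower number from compound 2 to compound 3 (0.39 log units; beyond the scatter). Compound 4, `C#CCn1cc(C(=O)NC(CC(=O)NC2CCCC2)c2ccccc2)c(=O)c2ccc(Cl)nc21`, differs from compound 3 by cyclopentyl in place of phenyl on an amide-type nitrogen. Of the measured steps only the second touches this amide-type nitrogen, and there the swap of one aryl group for another moved the number by a modest amount, starting from a limit. For the measured compounds named here, a switch from phenyl to cyclopentyl has no direct precedent in the set, so the size of the step cannot be anchored closely, and a return to the limit is possible. Compound 4 is expected to show a 1.5-fold higher number from compound 3 to compound 4 (0.18 log units; within the scatter) in this assay, a weakening or nothing beyond the scatter. The estimate for compound 4 is 6000 nM, within 2000 nM to 20000 nM.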

Compound 4, half-maximal inhibitory concentration: 7800 nM
Estimate against measurement, compound 4: 1.3-fold (0.11 log units) below; the range from low to high includes it.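

In this assay, cyclopentyl in place of phenyl on the amide-type nitrogen gives a 2.0-fold higher number from compound 3 to compound 4 (0.29 log units; within the scatter), so at this place an aromatic ring of carbon only is not needed for a measurable value. Against pyridin-2-yl on the same nitrogen the reading is an at least 1.2-fold lower number from compound 2 to compound 4 (0.10 log units; that floor lies within the scatter), and this floor alone does not separate the two groups. The pyridin-2-yl value of compound 2 is a limit of the assay and not a number: the limit of > 10000 nM in this assay, at which 2 of the 4 values shown sit.

Open, going by these compounds, is whether cyclohexyl, a longer alkyl chain or a carboxylic acid on this nitrogen would stay in the same range. Also open, on these data alone, is whether fluoro on the aromatic carbon, as carried by compound 1, would act the same way with cyclopentyl on the amide-type nitrogen.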